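A Straight Nonyl Chain in Place of a Branched One

This account rests on a few compounds, and the source may have more. Where it says the series, first, only, none or still open, it means among the compounds named here.

In a functional assay on KB cells (Homo sapiens) for cytotoxicity, read by resazurin assay, with a stated time of 3 days (on this read-out lower numbers stand for stronger inhibition and higher numbers for weaker inhibition), compound 1 `CCCCCC(=O)NCC(C)(C)CC1=C(O)C(=O)c2ccccc2C1=O` gives 40200 nM and compound 2 `CCCCCCC(C)C(=O)NCC(C)(C)CC1=C(O)C(=O)c2ccccc2C1=O` gives 23700 nM on this measure, which places the two within the usual scatter of each other. Compound 3 `CCCCCCCCCC(=O)NCC(C)(C)CC1=C(O)C(=O)c2ccccc2C1=O` differs from compound 2 by nonyl in place of 1-methylheptyl on a carbonyl carbon in one chain: nonyl in place of 1-methylheptyl on a carbonyl carbon. Going by the values given here, the only measured step (a 1.7-fold lower number from compound 1 to compound 2 (0.23 log units; within the scatter)) also changed the group on that carbonyl carbon and stayed small. No step beyond the scatter is therefore expected in this assay here. The estimated step is a 1.2-fold lower number from compound 2 to compound 3 (0.07 log units; within the scatter) in size. For compound 3 the expected value is 20000 nM with an estimated range of 8000 nM to 50000 nM in repeat measurements.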

Compound 3, half-maximal inhibitory concentration: 18500 nM
For compound 3 the middle estimate is 1.1-fold (0.03 log units) above the measured one, and the stated range covers the measured number.
By their numbers in this assay, from the lowest: compounds 3, 2 and 1 (each within the scatter of the next, the first and the last beyond it).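

In this assay, a straight chain and a branched chain on this carbonyl carbon stay within the scatter of each other, with nonyl in place of 1-methylheptyl (a 1.3-fold lower number from compound 2 to compound 3 (0.11 log units; within the scatter)). Set against the pentyl chain of compound 1, however, the nonyl chain gives the first step here beyond the scatter, though a modest one (a 2.2-fold lower number from compound 1 to compound 3 (0.34 log units; beyond the scatter)). No evidence is available to explain either step.

From the compounds shown here alone, whether a chain longer than nonyl would lower the number further remains open. So does the effect of ending the chain in an amine or a carboxylic acid.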